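Phenyl for Benzyl on the Chain Carbon in Microsomes

The source may report more compounds than this note shows. Statements on the series, on what has been measured and on what is new or still open speak of the compounds shown alone.

Compound 1, `CCC(CC)C(/C=C1\OC(=O)NC1=O)c1ccc(-c2ccc3cccc(F)c3c2)[nH]c1=O`: > 3 h
Compound 2, `O=C1NC(=O)/C(=C/C(Cc2ccccc2)c2ccc(-c3ccc4cccc(F)c4c3)[nH]c2=O)O1`: 2.96 h

Of the compounds shown here, two have been measured in an ADME assay on microsomes from liver (Rattus norvegicus) for metabolic stability; on this read-out higher numbers stand for a longer-lived compound and lower numbers for a shorter-lived compound. Among the compounds with values here, compound 1 is `CCC(CC)C(/C=C1\OC(=O)NC1=O)c1ccc(-c2ccc3cccc(F)c3c2)[nH]c1=O`; in this assay compound 1 gives > 3 h, which is a limit of the assay and not a number, the one value sitting at the limit of > 3 h in this assay, at which 1 of the 2 values shown sits. Within the data shown here, compound 2 is `O=C1NC(=O)/C(=C/C(Cc2ccccc2)c2ccc(-c3ccc4cccc(F)c4c3)[nH]c2=O)O1`; in this assay compound 2 gives 2.96 h, the only plain number in the set so far. Among the measured compounds shown here, the single measured step, benzyl in place of pentan-3-yl on a saturated chain carbon bound to an aromatic carbon and a double-bonded chain carbon, gave an at least 1.0-fold lower number from compound 1 to compound 2 (0.00 log units; that floor lies within the scatter).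

Compound 3 is `O=C1NC(=O)/C(=C/C(c2ccccc2)c2ccc(-c3ccc4cccc(F)c4c3)[nH]c2=O)O1`. It differs from compound 2 by phenyl in place of benzyl on a saturated chain carbon bound to an aromatic carbon and a double-bonded chain carbon. For the measured compounds named here, the one step at this same position did not move the half-life beyond the scatter, so the step from compound 2 to compound 3 is expected to be a 1.0-fold lower number from compound 2 to compound 3 (0.01 log units; within the scatter), with no clear direction. Compound 3 is therefore estimated at 2.9 h in this assay, in the range from 1.5 h to 5.5 h.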

Compound 3, half-life in the Rattus norvegicus assay: > 3 h
Compound 3: a limit, no number; the forecaster's own chance of this, stated with the estimate: 45%; middle value at least 1.0-fold (0.01 log units) from the limit.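

In the Rattus norvegicus assay, phenyl in place of benzyl gives an at least 1.0-fold higher number from compound 2 to compound 3 (0.00 log units; that floor lies within the scatter), a floor only, so this position has still shown no half-life change beyond the scatter. Compound 3, like compound 1, carries a limit of the assay and not a number, and the step between these two compounds cannot be read: the limit of > 3 h in the Rattus norvegicus assay, at which 2 of the 3 values shown sit.

What is new is a second read-out for the same change, for in a physicochemical assay for solubility, measured as kinetic solubility, at pH 2 (a lower number here means a less soluble compound, a higher number a more soluble compound), compound 2 gives 900 nM and compound 3 gives 15400 nM, which is a 17-fold higher number from compound 2 to compound 3 (1.23 log units; beyond the scatter), so that this one change on the saturated chain carbon gives a step beyond the scatter in this assay. The floor in the Rattus norvegicus assay stays within the scatter.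

Going by these compounds, how far the half-lives of compound 1 and compound 3 lie past the limit in the Rattus norvegicus assay stays open, and so does any order between them. Also open, on these data alone, is how an amine or a carboxylic acid on this chain carbon, in place of phenyl, would read in the Rattus norvegicus assay and in the physicochemical assay.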